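Losing activity in the methylated series: from compound 2 to compound 4

The source may report more compounds than this note shows. Statements on the series, on what has been measured and on what is new or still open speak of the compounds shown alone.

Values in a functional assay on the whole organism for agonist activity, with Mus musculus as the target; a lower number here means that less compound is needed, a higher number that more compound is needed for the effect:
- compound 1 `CC(=O)N(C)C(C)C#CCn1ccnc1`: 3 mg/kg
- compound 2 `CC(=O)N(C)C(C)C#CCn1cncc1C`: > 100 mg/kg
- compound 3 `COC(=O)NCC#CCn1cncc1C`: > 100 mg/kg

Compound 2 has no numerical value in this assay, only the limit > 100 mg/kg. Compound 3 is also reported only as a limit, > 100 mg/kg. Compound 2 and compound 3 therefore share (the limit of > 100 mg/kg in this assay, at which 2 of the 3 values shown sit).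

The next compound is compound 4 `CCOC(=O)N(C)C(C)C#CCn1cncc1C`, which differs from compound 2 by one change on the acyl side: ethoxy in place of methyl on a carbonyl carbon. Put another way, the acetyl of compound 2 becomes ethoxycarbonyl in compound 4.

Among the measured compounds shown here, the only measured step is an at least 33-fold higher number from compound 1 to compound 2 (1.52 log units; beyond the scatter), which is large and comes with methyl in place of hydrogen on an aromatic carbon. Compound 4 keeps that methyl. For the measured compounds named here, no step has been measured for the change at the carbonyl carbon. Recovery of a measurable dose is therefore not expected, and no step beyond the scatter is foreseen in this assay. The expected result is a number no higher from compound 2 to compound 4 (the limit leaves the size open). For compound 4 the estimated value is 100 mg/kg, with an expected range of 30 mg/kg to 300 mg/kg.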

Compound 4, dose for half-maximal effect: > 100 mg/kg
Compound 4: only a limit was reported; the forecaster's own chance of this, stated with the estimate: 85%; the middle value sits exactly at the limit.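

Compound 2 and compound 4 are each reported only as a limit in this assay, so no step can be read between them: the limit of > 100 mg/kg in this assay, at which 3 of the 4 values shown sit.

The compounds shown leave open whether ethoxy in place of methyl on a carbonyl carbon changes the dose at all, and whether any compound carrying the methyl on the aromatic carbon reaches a measurable dose.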